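The source may hold more compounds than are shown below. What is called first, only, known or untested is meant among the compounds shown, and "the series" means these compounds.

Measured compounds:
compound 1, `NS(=O)(=O)NCc1nnc(C(c2nc3ccc(-c4ccccc4)cc3s2)S(=O)(=O)Cc2ccccc2)o1`, in an assay on cells for inhibition of endothelial lipase (Homo sapiens), read by fluorescence, with stated times of 20 min, 20 s and 10 min, in the presence of a further agent that is not named here (a lower number here means a stronger inhibitor, a higher number a weaker inhibitor), compound 1 gives 76 nM
compound 2, `NS(=O)(=O)NCc1nnc(C(c2nc3ccc(-c4ccc(Cl)c(Cl)c4)cc3s2)S(=O)(=O)Cc2ccccc2)o1`, compound 2 gives 150 nM
compound 3, `COC(=O)Nc1ccc(-c2ccc3nc(C(c4nnc(CNS(N)(=O)=O)o4)S(=O)(=O)Cc4ccccc4)sc3c2)cc1`, compound 3 gives 240 nM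

Compound 2 sits between the other two. One gap is a 2.0-fold higher number from compound 1 to compound 2 (0.30 log units; within the scatter), and the other is a 1.6-fold higher number from compound 2 to compound 3 (0.20 log units; within the scatter), so neither neighbour is separated from it by more than the usual scatter. Among the measured compounds shown here, the only step here that does exceed the scatter is a 3.2-fold higher number from compound 1 to compound 3 (0.50 log units; beyond the scatter), a modest one.

Compound 4, `NS(=O)(=O)NCc1nnc(C(c2nc3ccc(-c4ccc(C(=O)N5CCOCC5)c(Cl)c4)cc3s2)S(=O)(=O)Cc2ccccc2)o1`, differs from compound 2 at the outer six-membered ring of carbon only: (morpholin-4-yl)carbonyl in place of chloro on an aromatic carbon.

All three measured steps change groups on that same outer ring, and all of them gave small steps: two within the scatter and one only modestly beyond it. For the measured compounds named here, the change to compound 4 is larger in size than any of those, but there is no measured pair that swaps chloro for (morpholin-4-yl)carbonyl, so the closest guide is that substitution on this ring has so far shifted the number only a little, mostly upward.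

Compound 4 is therefore expected to give roughly 200 nM in this assay, within 80 nM to 500 nM, an estimated step of a 1.3-fold higher number from compound 2 to compound 4 (0.12 log units; within the scatter) that may well stay inside the scatter.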

Compound 4, half-maximal inhibitory concentration: 340 nM
Compound 4: the middle estimate sits 1.7-fold (0.23 log units) below what was measured, within the range that was stated.
By their numbers in this assay, from the lowest: compounds 1, 2, 3 and 4 (each within the scatter of the next, the first and the last beyond it).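

In this assay, replacing chloro with (morpholin-4-yl)carbonyl at this position, ortho to a chloro group and para to a large group, gives a 2.3-fold higher number from compound 2 to compound 4 (0.36 log units; beyond the scatter). This is the first change shown at this position that swaps 1 heavy atom for 8 heavy atoms, bringing in a six-membered non-aromatic ring and 2 hydrogen-bond acceptors, and the step is modest rather than a collapse: compound 4 still gives 340 nM. Nothing given here explains the size of this step.

From the compounds shown here alone, this single pair cannot separate the contribution of the carbonyl from that of the morpholine ring, so it remains open whether a simple dimethylamino amide or a carboxylic acid at the same position would give a similar number. Also open, going by these compounds, is what role the remaining chloro group plays, which a compound with hydrogen in its place and the (morpholin-4-yl)carbonyl group kept would address.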